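Methyl added to the cyclobutane ring of compound 2

This account rests on a few compounds, and the source may have more. Where it says the series, first, only, none or still open, it means among the compounds named here.

Measured so far:
compound 1 `C[C@]1(O)C[C@](c2ccnc(C(F)(F)F)c2)([C@H](O)c2ccccn2)C1` with 500 nM
compound 2 `O[C@H](c1ccccn1)[C@]1(c2ccnc(C(F)(F)F)c2)C[C@@H](O)C1` with 530 nM

In an assay on HEK293 cells for antagonist activity at transient receptor potential cation channel subfamily V member 3 (Homo sapiens), read by FLIPR and calcium flux (a lower number here means a stronger inhibitor, a higher number a weaker inhibitor), compound 2 gives 530 nM, the higher of the two numbers, yet its nearest neighbour compound 1 gives 500 nM, and the gap between them lies within the scatter, so no order between the two can be read. Compound 3 `C[C@]1(O)C[C@@](c2ccnc(C(F)(F)F)c2)([C@H](O)c2ccccn2)C1` has not yet been measured in this assay. It differs from compound 2 by methyl in place of hydrogen on a saturated ring carbon. For the measured compounds named here, no step between measured compounds is on record for this change, so the expected size rests on the two values alone. Compound 1 also bears a methyl on its four-membered ring and gives 500 nM, so no step beyond the scatter is expected here. Compound 3 is therefore expected to give about 450 nM in this assay, between 200 nM and 1200 nM. The estimated step of a 1.2-fold lower number from compound 2 to compound 3 (0.07 log units; within the scatter) is small.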

Compound 3, antagonist equilibrium constant: 4270 nM
The estimate for compound 3 lay 9.5-fold (0.98 log units) below the measured number; the whole stated range lies below it.
By their numbers in this assay, from the lowest: compounds 1 and 2 (each within the scatter of the next); then compound 3.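

In this assay, methyl in place of hydrogen on this saturated ring carbon of the four-membered ring has no single effect: its outcome depends on the configuration in which it is drawn. In one configuration, the change brings an 8.1-fold higher number from compound 2 to compound 3 (0.91 log units; beyond the scatter), while compound 1 carries the same methyl on the same ring and its number stays within the scatter of that of compound 2. The step of an 8.5-fold higher number from compound 1 to compound 3 (0.93 log units; beyond the scatter) can therefore be assigned to configuration alone, because of this: the fact that compounds 1 and 3 differ only in the configuration as drawn.

As far as these compounds go, it remains open whether the reversed configuration has a comparable effect on the ring without the methyl. Also open, from the compounds shown here alone, is whether an ethyl group or a methoxy group on this ring carbon would follow compound 1 or compound 3.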